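Halogen pattern on the benzyl group and growth inhibition

This account rests on a few compounds, and the source may have more. Where it says the series, first, only, none or still open, it means among the compounds named here.

Measured so far:
compound 1 `Ic1ccc(Cn2cc(CCCOc3cccc4cccnc34)nn2)cc1` gives 24.6 ug/mL
compound 2 `Clc1ccc(Cn2cc(CCCOc3cccc4cccnc34)nn2)cc1` gives 11.2 ug/mL
compound 3 `Clc1cc(Cl)c(Cn2cc(CCCOc3cccc4cccnc34)nn2)c(Cl)c1` gives 7.4 ug/mL

All three were read in a functional assay on NCI-H460 cells (Homo sapiens) for inhibition, read by sulforhodamine B assay, with a stated time of 48 h; on this read-out higher numbers stand for weaker inhibition of growth and lower numbers for stronger inhibition of growth. Compound 1 stands highest of the three numbers, that is, it is the weakest growth inhibitor of the set. The step of a 2.2-fold lower number from compound 1 to compound 2 (0.34 log units; beyond the scatter) is modest but beyond the scatter; the step of a 3.3-fold lower number from compound 1 to compound 3 (0.52 log units; beyond the scatter) is also modest and beyond the scatter, while the step of a 1.5-fold lower number from compound 2 to compound 3 (0.18 log units; within the scatter) stays within the scatter, so compound 2 and compound 3 cannot be ordered against each other.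

Compound 4 `Clc1ccc(Br)cc1Cn1cc(CCCOc2cccc3cccnc23)nn1` is the next member, not yet measured. Relative to compound 1 the change is 5-bromo-2-chlorophenyl in place of 4-iodophenyl on a saturated chain carbon bound to an aromatic nitrogen.

Both measured steps from compound 1 bear on this: each replaces the iodo-bearing ring with one carrying chlorine, and each lowers the number modestly. Compound 4 also swaps iodine for chlorine and bromine on the ring, so a modest lowering is expected, roughly of the size seen from compound 1 to compound 2 and compound 3, giving an expected step of a 2.2-fold lower number from compound 1 to compound 4 (0.35 log units; beyond the scatter). Compound 4 is therefore estimated at 11 ug/mL, with a likely range from 5.5 ug/mL to 24 ug/mL.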

Compound 4, concentration for 50% growth inhibition: 7.9 ug/mL
Estimate against measurement, compound 4: 1.4-fold (0.14 log units) above; measured number inside the range.
By their numbers in this assay, from the lowest: compounds 3, 4 and 2 (each within the scatter of the next); then compound 1.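

In this assay the series shows a 3.1-fold lower number from compound 1 to compound 4 (0.49 log units; beyond the scatter), so a third replacement of 4-iodophenyl on a saturated chain carbon bound to an aromatic nitrogen lowers the number beyond the scatter, and here the entering ring carries bromine as well as chlorine. Against the two chlorine-only rings, the data give a 1.1-fold higher number from compound 3 to compound 4 (0.03 log units; within the scatter) and a 1.4-fold lower number from compound 2 to compound 4 (0.15 log units; within the scatter), so compounds 2, 3 and 4 cannot be ordered against each other, and compound 1 alone stands apart as the weakest growth inhibitor of the four. No measurement at hand accounts for the separation of compound 1 from the other three or for the closeness of those three.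

The compounds shown contain no pair in which a single halogen changes or moves while the rest of the ring stays the same, so the contributions of halogen type, number and placement remain unseparated. They also leave open how an amine or a carboxylic acid on the benzyl ring, or a longer chain joining the two ends of the core, would read in this assay.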